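Carboxymethyl to 1-carboxyethyl on the amide nitrogen

This account rests on a few compounds, and the source may have more. Where it says the series, first, only, none or still open, it means among the compounds named here.

In a functional assay on PC-3 cells (Homo sapiens) for antiproliferative activity, read by MTT assay, with a stated time of 24 h (on this read-out higher numbers stand for weaker inhibition and lower numbers for stronger inhibition), compound 1 `CCN(CC)CCNC(=O)c1ccc(C(CC)(CC)c2ccc(OCS(=O)(=O)c3ccccc3)c(C)c2)n1CC` gives 7130 nM and compound 2 `CCn1c(C(=O)N[C@@H](CO)CCO)ccc1C(CC)(CC)c1ccc(OCS(=O)(=O)c2ccccc2)c(C)c1` gives 14100 nM while compound 3 `CCn1c(C(=O)NCC(=O)O)ccc1C(CC)(CC)c1ccc(OCS(=O)(=O)c2ccccc2)c(C)c1` gives 30100 nM as the highest number of the three. Compound 4 `CCn1c(C(=O)N[C@H](C)C(=O)O)ccc1C(CC)(CC)c1ccc(OCS(=O)(=O)c2ccccc2)c(C)c1` differs from compound 3 by methyl in place of hydrogen on a saturated chain carbon bound to an amide-type nitrogen and a carbonyl carbon in the form of methyl in place of hydrogen on a saturated chain carbon bound to an amide-type nitrogen and a carbonyl carbon, turning carboxymethyl into 1-carboxyethyl. Among the measured compounds shown here, no measured step isolates this change. The measured steps exchange whole substituents: a 4.2-fold higher number from compound 1 to compound 3 (0.63 log units; beyond the scatter) is modest and a 2.0-fold higher number from compound 1 to compound 2 (0.30 log units; within the scatter) lies within the scatter. Even a 2.1-fold higher number from compound 2 to compound 3 (0.33 log units; beyond the scatter) is only modest for a whole exchanged substituent, so methyl alone is expected to give no step beyond the scatter in this assay here. The estimated change is a 1.1-fold lower number from compound 3 to compound 4 (0.05 log units; within the scatter) and stays within the scatter. Compound 4 is expected at 27000 nM within a range from 13000 nM to 55000 nM for now.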

Compound 4, half-maximal inhibitory concentration: 20100 nM
Compound 4: the middle estimate sits 1.3-fold (0.13 log units) above what was measured, and the stated range covers the measured number.
By their numbers in this assay, from the lowest: compounds 1, 2, 4 and 3 (each within the scatter of the next, the first and the last beyond it).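

In this assay, among the compounds shown here, methyl in place of hydrogen on a saturated chain carbon bound to an amide-type nitrogen and a carbonyl carbon gives a 1.5-fold lower number from compound 3 to compound 4 (0.18 log units; within the scatter) as the first single-atom change at this position. With 1-carboxyethyl on the amide-type nitrogen, a 1.4-fold higher number from compound 2 to compound 4 (0.15 log units; within the scatter) also stays within the scatter, whereas a 2.8-fold higher number from compound 1 to compound 4 (0.45 log units; beyond the scatter) remains modest, so the gap to the 2-(diethylamino)ethyl amide persists with this group. No evidence bears on the reason for these steps.

Open, from the compounds shown here alone, is whether ethyl or a longer chain on this carbon would also stay within the scatter. Going by these compounds, a methyl ester in place of the carboxylic acid also remains open.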